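The compounds below may be only part of what the source reports. "The series", "measured", "known", "first", "only" and "open" are said of these compounds alone.

Measured so far in a functional assay on HT-29 cells (Homo sapiens) for inhibition, read by MTT assay, with a stated time of 72 h; on this read-out lower numbers stand for stronger inhibition and higher numbers for weaker inhibition:
compound 1 `C=C(Br)C(=O)Nc1cccc(/C=C/C(=O)Nc2ccc(F)c(F)c2)c1`: 8700 nM
compound 2 `C=C(Br)C(=O)Nc1cccc(/C=C/C(=O)Nc2ccc(Cl)cc2)c1`: 7900 nM
compound 3 `C=C(Br)C(=O)Nc1cccc(/C=C/C(=O)NCc2ccc(C)cc2)c1`: 2700 nM

Compound 3 has the lowest number of the three, and its gaps to the other two lie beyond the scatter. The next compound, compound 4 `C=C(Br)C(=O)Nc1cccc(/C=C/C(=O)Nc2ccc(OC)cc2)c1`, carries 4-methoxyphenyl in place of 4-methylbenzyl on an amide-type nitrogen.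

Going by the values given here, three measured steps bear on this change. Moving to 4-methylbenzyl gave a 3.2-fold lower number from compound 1 to compound 3 (0.51 log units; beyond the scatter) and a 2.9-fold lower number from compound 2 to compound 3 (0.47 log units; beyond the scatter), while exchanging one phenyl group for the other gave a 1.1-fold lower number from compound 1 to compound 2 (0.04 log units; within the scatter). Among the compounds with values here, compound 4 again has a substituted phenyl on that nitrogen, so a reversal of the two modest steps is expected, although no compound with 4-methoxyphenyl has yet been measured. The expected step in this assay is a 2.6-fold higher number from compound 3 to compound 4 (0.41 log units; beyond the scatter), modest and toward a higher number. For compound 4 the estimate is 7000 nM, with an expected range from 3500 nM to 14000 nM.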

Compound 4, half-maximal inhibitory concentration: 2300 nM
For compound 4 the middle estimate is 3.0-fold (0.48 log units) above the measured one; the measured number lies below the stated range.
By their numbers in this assay, from the lowest: compounds 4 and 3 (each within the scatter of the next); then compounds 2 and 1 (each within the scatter of the next).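

In this assay, a substituted phenyl on the amide-type nitrogen does not by itself go with the higher numbers: 4-methoxyphenyl in place of 4-methylbenzyl gives a 1.2-fold lower number from compound 3 to compound 4 (0.07 log units; within the scatter), so this exchange cannot be told apart from the scatter. The substituent on the phenyl now separates the compounds, with methoxy in place of chloro giving a 3.4-fold lower number from compound 2 to compound 4 (0.54 log units; beyond the scatter) and 4-methoxyphenyl in place of 3,4-difluorophenyl giving a 3.8-fold lower number from compound 1 to compound 4 (0.58 log units; beyond the scatter), both modest steps. Nothing measured here explains these differences.

Open, as far as these compounds go, is how an amine or a carboxylic acid on that aromatic carbon would compare with methoxy. Also open, from the compounds shown here alone, is whether 4-methoxybenzyl on the amide-type nitrogen would give a number in line with compound 3 and compound 4.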